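Removing One Methoxy Group from Compound 1

The compounds below may be only part of what the source reports. "The series", "measured", "known", "first", "only" and "open" are said of these compounds alone.

Of the compounds shown here, three have been measured so far: compound 1 `COc1cc(-c2cc(/C=C/C(=O)c3ccc(N)cc3)[nH]n2)cc(OC)c1OC` with 3990 nM, compound 2 `COc1ccc(-c2cc(/C=C/C(=O)c3ccc(OC)c(OC)c3)[nH]n2)cc1` with 1390 nM, and compound 3 `COc1cc(-c2cc(/C=C/C(=O)c3ccc(Cl)c(Cl)c3)[nH]n2)cc(OC)c1OC` with 3040 nM, all in a functional assay on NCI-H522 cells (Homo sapiens) for inhibition, read by sulforhodamine B assay, with a stated time of 48 h; a higher number here means a weaker inhibitor of growth, a lower number a stronger inhibitor of growth.

Among these three, compound 1 has the highest number, that is, the weakest growth inhibition. Compound 3 sits nearest to it, and the step of a 1.3-fold lower number from compound 1 to compound 3 (0.12 log units; within the scatter) is too small to count as a real difference. Compound 2 lies furthest away, at a lower number that does stand beyond the scatter.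

Compound 4 `COc1ccc(-c2cc(/C=C/C(=O)c3ccc(N)cc3)[nH]n2)cc1OC` has not yet been measured. It differs from compound 1 in one place: hydrogen in place of methoxy on an aromatic carbon. The change is small, a single methoxy group gone from an aromatic ring that still carries two others.

Within the data shown here, no measured step here alters that same group, so there is nothing among the three compounds that speaks directly to this change. Among the measured compounds shown here, the one step that is known, a 1.3-fold lower number from compound 1 to compound 3 (0.12 log units; within the scatter), concerns the other end of the molecule and stayed within the scatter. In the absence of a bearing step, the expectation is that compound 4 behaves much like compound 1, giving an estimated step of a 1.1-fold lower number from compound 1 to compound 4 (0.06 log units; within the scatter), with no clear direction beyond the scatter. The estimated value for compound 4 is therefore 3500 nM, with a likely range from 1200 nM to 10000 nM.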

Compound 4, concentration for total growth inhibition: 3220 nM
Compound 4: middle estimate off by 1.1-fold (0.04 log units), on the high side; the range from low to high includes it.
By their numbers in this assay, from the lowest: compound 2; then compounds 3, 4 and 1 (each within the scatter of the next).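

In this assay, among these compounds, hydrogen in place of methoxy gives a 1.2-fold lower number from compound 1 to compound 4 (0.09 log units; within the scatter), so this is the first direct reading at this position, and it shows no real difference between the two groups. The position is on an aromatic carbon ortho to a methoxy group and meta to a large group, and the step here stays as small as the one at the other end of the molecule. Nothing measured here offers an explanation for this result. Going by these compounds, it remains open whether a different group at this position, such as an amine, a carboxylic acid or a longer chain, would give a step beyond the scatter. Also open, on these data alone, is whether removing this methoxy group would read the same with the 3,4-dichlorophenyl of compound 3 in place of the 4-aminophenyl.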